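The source may hold more compounds than are shown below. What is called first, only, known or untested is meant among the compounds shown, and "the series" means these compounds.

Values in an ADME assay on HepG2 2.2.15 cells (Homo sapiens) for cytotoxicity; on this read-out lower numbers stand for higher toxicity in this test and higher numbers for lower toxicity in this test:
compound 1 `O=c1c(CCO)c(-c2ccccc2Cl)c2cc(Cl)ccc2n1-c1ccccc1`: 26000 nM
compound 2 `O=c1c(CCO)c(-c2ccccc2Cl)c2cc(Cl)ccc2n1-c1c(F)cccc1F`: > 2300000 nM (a limit of the assay, not a number)
compound 3 `CCCC(=O)OCCc1c(-c2ccccc2Cl)c2cc(Cl)ccc2[nH]c1=O`: 52000 nM

Compound 1 at 26000 nM and compound 3 at 52000 nM lie within the scatter of each other. Compound 2 is known only as a limit, (the limit of > 2300000 nM in this assay, at which 1 of the 3 values shown sits), so compound 3 has a single true number to stand against.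

The next compound is compound 4 `COCC(=O)OCCc1c(-c2ccccc2Cl)c2cc(Cl)ccc2[nH]c1=O`, and the change is methoxy in place of ethyl on a saturated chain carbon bound to a carbonyl carbon: propylcarbonyl becomes (methoxymethyl)carbonyl.

Within the data shown here, the only measured step is an at least 88-fold higher number from compound 1 to compound 2 (1.94 log units; beyond the scatter). It is large, but it lies on an aromatic nitrogen, a different place from this change, so it does not bear on it. Among the measured compounds shown here, no measured step covers the group that changes here. The best anchor is therefore compound 3 at 52000 nM, and no step beyond the scatter is expected.

The expected step is a 1.2-fold lower number from compound 3 to compound 4 (0.06 log units; within the scatter).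

Compound 4 is estimated at 45000 nM, with an expected range of 18000 nM to 120000 nM.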

Compound 4, half-maximal cytotoxic concentration: 74000 nM
For compound 4 the middle estimate is 1.6-fold (0.22 log units) below the measured one, and the stated range covers the measured number.
By their numbers in this assay, from the lowest: compounds 1, 3 and 4 (each within the scatter of the next, the first and the last beyond it). At a limit, above all of these: compound 2.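

In this assay methoxy in place of ethyl on a saturated chain carbon bound to a carbonyl carbon gives a 1.4-fold higher number from compound 3 to compound 4 (0.15 log units; within the scatter), so propylcarbonyl and (methoxymethyl)carbonyl cannot be told apart on this read-out. Among these compounds, this is the first measured step at this place, and it shows that adding the oxygen to the chain leaves the number within the scatter, unlike the large step seen earlier on an aromatic nitrogen, which lies elsewhere on the molecule. Nothing measured here gives a reason for this step.

From the compounds shown here alone, whether an amine, a carboxylic acid or a longer chain at this place would move the number beyond the scatter remains open. Also open, going by these compounds, is whether 2,6-difluorophenyl on the aromatic nitrogen would give a similar step alongside (methoxymethyl)carbonyl.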